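Swapping the amine on the chain carbon of compound 3

The source may report more compounds than this note shows. Statements on the series, on what has been measured and on what is new or still open speak of the compounds shown alone.

Three compounds have numbers in a functional assay on MDA-MB-468 cells (Homo sapiens) for cytotoxicity, read by sulforhodamine B assay, with a stated time of 48 h; on this read-out lower numbers stand for stronger inhibition of growth and higher numbers for weaker inhibition of growth:

Compound 1, `O=C1C(=O)N(CN(c2ccccc2)c2ccccc2)c2ccccc21`, gives 21500 nM.
Compound 2, `Cc1ccc2nc(/N=C3\C(=O)N(CN(c4ccccc4)c4ccccc4)c4cccc(Br)c43)sc2c1`, gives 82300 nM.
Compound 3, `CN(C)CN1C(=O)C(=O)c2c(Br)cccc21`, gives 49000 nM.

Compound 3 sits at the second highest of the three numbers. Its number and that of compound 2 lie within the scatter of each other, so the two cannot be told apart on this read-out. Compound 1, which carries the diphenylamino arm and no bromine, gives a lower number than compound 3, and that gap is beyond the scatter.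

Compound 4, `O=C1C(=O)N(CN2CCCCC2)c2cccc(Br)c21`, is not yet measured. It differs from compound 3 in one place: piperidin-1-yl in place of dimethylamino on a saturated chain carbon bound to an amide-type nitrogen in a ring. Going by the values given here, both the leaving and the entering group are tertiary amines on the same chain carbon, and no measured pair in this set shows what such an exchange does. The account therefore expects no step beyond the scatter in either direction, with compound 3 at 49000 nM as the anchor. The estimated step in this assay from compound 3 to compound 4 is a 1.2-fold lower number from compound 3 to compound 4 (0.07 log units; within the scatter). Compound 4 is expected to give about 42000 nM, with a likely range from 15000 nM to 120000 nM.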

Compound 4, concentration for 50% growth inhibition: 35300 nM
The estimate for compound 4 lay 1.2-fold (0.08 log units) above the measured number; measured number inside the range.
By their numbers in this assay, from the lowest: compounds 1, 4, 3 and 2 (each within the scatter of the next, the first and the last beyond it).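

In this assay, going by these compounds alone, piperidin-1-yl in place of dimethylamino on a saturated chain carbon bound to an amide-type nitrogen in a ring gives a 1.4-fold lower number from compound 3 to compound 4 (0.14 log units; within the scatter), and this is the first pair in the set that differs in one place. It shows that, at this chain carbon, an open tertiary amine can give way to one held in a six-membered non-aromatic ring with no step beyond the scatter, so the read-out does not tell these two arms apart. Nothing measured here bears on why the two amines read alike.

The compounds shown leave open whether an amine with a second hetero atom in its ring, such as morpholin-4-yl or 4-methylpiperazin-1-yl, or a secondary amine with a hydrogen on its nitrogen, would also stay within the scatter of compound 3 at this chain carbon. Equally open, going by these compounds, is what the bromine does by itself, as compound 1 and compound 2 each differ from compound 4 in more than one place.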